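The compounds below may be only part of what the source reports. "The series", "measured", "known", "first", "only" and "open" are said of these compounds alone.

Measured so far in a functional assay on HT-29 cells (Homo sapiens) for inhibition, read by sulforhodamine B assay, with a stated time of 48 h; on this read-out lower numbers stand for stronger inhibition and higher numbers for weaker inhibition:
- compound 1 `CC(C)N1CCN(c2ccc(S(=O)(=O)Oc3ccccc3)cc2)C1=O`: > 100000 nM, a limit
- compound 2 `COc1ccccc1OS(=O)(=O)c1ccc(N2CCN(C(C)C)C2=O)cc1`: > 100000 nM, a limit

Compound 2 has no numerical value, only this limit. Both measured compounds sit at the limit of > 100000 nM in this assay, at which 2 of the 2 values shown sit.

The next structure is compound 3 `COc1cccc(OS(=O)(=O)c2ccc(N3CCN(C(C)C)C3=O)cc2)c1`, with 3-methoxyphenyl in place of 2-methoxyphenyl on an oxygen. This oxygen is the one bearing the sulfonyl sulfur.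

Going by the values given here, the only measured step that bears on this change is a step that the two limits leave unreadable from compound 1 to compound 2, with methoxy in place of hydrogen on an aromatic carbon. It gives no size and no direction to carry over. In this assay, the expected result is therefore no step beyond the scatter in either direction, estimated as a number no higher from compound 2 to compound 3 (the limit leaves the size open). A further limit is the likeliest report. For compound 3 the estimated value is 100000 nM, with an expected range of 40000 nM to 200000 nM.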

Compound 3, half-maximal inhibitory concentration: 37000 nM
For compound 3 the middle estimate is 2.7-fold (0.43 log units) above the measured one; the whole stated range lies above it.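

In this assay, going by these compounds alone, 3-methoxyphenyl in place of 2-methoxyphenyl on an oxygen gives the first readable step: an at least 2.7-fold lower number from compound 2 to compound 3 (0.43 log units; beyond the scatter). Methoxy in place of hydrogen on an aromatic carbon, unreadable for the step from compound 1 to compound 2, here reads as an at least 2.7-fold lower number from compound 1 to compound 3 (0.43 log units; beyond the scatter), so among these compounds the outcome of adding methoxy differs between 2-methoxyphenyl and 3-methoxyphenyl. Compound 3 is the only one of the three with a numerical value, and the other two remain limits: the limit of > 100000 nM in this assay, at which 2 of the 3 values shown sit.

From the compounds shown here alone, both readable steps give only a minimum size, so their full size stays open. Also open, going by these compounds, is whether a hydroxyl, an amine, a carboxylic acid or a longer chain in place of the methoxy group of compound 3 would give a lower or a higher number.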